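Swapping the Sulfur Side Chain on a Dimethylamino Compound

The source may hold more compounds than are shown below. What is called first, only, known or untested is meant among the compounds shown, and "the series" means these compounds.

Measured in a functional assay on HCT-116 cells (Homo sapiens) for inhibition, read by MTT assay, with a stated time of 48 h; on this read-out higher numbers stand for weaker inhibition and lower numbers for stronger inhibition:
- compound 1 `COc1ccc(CSc2nnc(-c3cc(OC)c(OC)c(OC)c3)n2-c2ccc(OC)cc2)cc1`: 49600 nM
- compound 2 `COc1ccc(C(=O)CSc2nnc(-c3cc(OC)c(OC)c(OC)c3)n2-c2ccc(OC)cc2)cc1`: > 60000 nM (a limit of the assay, not a number)
- compound 3 `COc1ccc(CSc2nnc(-c3cc(OC)c(OC)c(OC)c3)n2-c2ccc(N(C)C)cc2)cc1`: 1150 nM

Among the two actual numbers, compound 3 has the lower value, at 1150 nM. Its gain is large: a 43-fold lower number from compound 1 to compound 3 (1.63 log units; beyond the scatter), which follows the exchange of methoxy for dimethylamino on an aromatic carbon.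

The next compound is compound 4 `COc1cc(-c2nnc(SCC(=O)c3ccc4ccccc4c3)n2-c2ccc(N(C)C)cc2)cc(OC)c1OC`. It keeps that dimethylamino group, but its side chain changes: (naphthalen-2-yl)carbonyl in place of 4-methoxyphenyl on a saturated chain carbon bound to a sulfur. In words, (naphthalen-2-yl)carbonyl stands in place of 4-methoxyphenyl on a saturated chain carbon bound to a sulfur.

Among the compounds with values here, two measured steps bear on this. The closest is the introduction of the carbonyl, an at least 1.2-fold higher number from compound 1 to compound 2 (0.08 log units; that floor lies within the scatter). From the compounds shown here alone, that figure is only a floor, resting on (the limit of > 60000 nM in this assay, at which 1 of the 3 values shown sits), so the true size of the step remains open, and it could be small or large. The step of a 43-fold lower number from compound 1 to compound 3 (1.63 log units; beyond the scatter) suggests that the retained dimethylamino group may preserve much of the gain seen in compound 3. Within the data shown here, no measured compound carries the naphthalene-containing group, so its contribution is unknown.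

A moderate loss is therefore expected, though with wide uncertainty. The estimated change is a 2.6-fold higher number from compound 3 to compound 4 (0.42 log units; beyond the scatter). For compound 4 the expected value in this assay is 3000 nM, with an estimated range from 400 nM to 25000 nM.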

Compound 4, half-maximal inhibitory concentration: 54500 nM
For compound 4 the middle estimate is 18-fold (1.26 log units) below the measured one; the measured number lies above the stated range.
By their numbers in this assay, from the lowest: compound 3; then compounds 1 and 4 (each within the scatter of the next). At a limit, above all of these: compound 2.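

In this assay, the side chain on the saturated chain carbon bound to a sulfur matters strongly even when the dimethylamino group stays in place: (naphthalen-2-yl)carbonyl in place of 4-methoxyphenyl gives a 47-fold higher number from compound 3 to compound 4 (1.68 log units; beyond the scatter). Within the data shown here, until now the only large step that could be read was the one at the aromatic carbon, a 43-fold lower number from compound 1 to compound 3 (1.63 log units; beyond the scatter), and this result shows that keeping dimethylamino does not by itself hold on to that gain. The new group differs from the old one in two ways at once, adding a carbonyl and a second aromatic ring, so this single step cannot say which of the two carries the loss.

Separating them would take naphthalen-2-yl without the carbonyl, or (4-methoxyphenyl)carbonyl on the dimethylamino compound, and a side chain ending in an amine would test a quite different kind of group at this place. The size of the effect of the carbonyl on its own also stays unknown, since compound 2 gives only a limit of the assay and not a number: the limit of > 60000 nM in this assay, at which 1 of the 4 values shown sits.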